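From compound 3 to compound 4: an aryl swap

The source may report more compounds than this note shows. Statements on the series, on what has been measured and on what is new or still open speak of the compounds shown alone.

- compound 1 `Cc1cc(=O)c2c(O)cc(OCc3ccco3)c([C@H]3CCN(C)C[C@H]3O)c2o1`: 14%
- compound 2 `Cc1cc(=O)c2c(O)c(CN3CC(O)CC3C(=O)O)c(O)c([C@H]3CCN(C)C[C@H]3O)c2o1`: 0%
- compound 3 `Cc1oc2c([C@H]3CCN(C)C[C@H]3O)c(O)cc(O)c2c(=O)c1C(O)c1ccccc1Br`: 45%

All three values come from a functional assay on PC-3 cells (Homo sapiens) for inhibition, read by MTT assay, with a stated time of 48 h, tested at 10 uM; a higher number here means more inhibition of growth at the concentration tested, a lower number less inhibition of growth. Compound 3 stands highest of the three, and its gaps to compound 1 and to compound 2 both lie beyond the scatter. The next compound to be tested is compound 4 `Cc1oc2c([C@H]3CCN(C)C[C@H]3O)c(O)cc(O)c2c(=O)c1C(O)c1cccc(Cl)c1Cl`. Within the data shown here, its single change from compound 3 is 2,3-dichlorophenyl in place of 2-bromophenyl on a saturated chain carbon bound to an aromatic carbon and an oxygen on a saturated carbon.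

Among the measured compounds shown here, no two measured compounds differ in only one place, so the data give no direct measure of an aryl change in this assay. For the measured compounds named here, the only close reference is compound 3 at 45%, so no step beyond the scatter is expected, in either direction. The expected size of the move is a number 3 percentage points higher from compound 3 to compound 4 (within the scatter). For compound 4 the estimated value is 48%, with an expected range from 28% to 68%.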

Compound 4, percent growth inhibition at one concentration: 20%
Beside the measured number, compound 4's estimate is 28 percentage points above it; the whole stated range lies above it.
By their numbers in this assay, from the lowest: compound 2; then compounds 1 and 4 (each within the scatter of the next); then compound 3.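

Among these compounds, replacing 2-bromophenyl with 2,3-dichlorophenyl gives a number 25 percentage points lower from compound 3 to compound 4 (beyond the scatter) in this assay, the first comparison that isolates a single change. The aryl group on this saturated chain carbon therefore affects growth inhibition at the concentration tested, and two halogen-bearing phenyl groups are not interchangeable here. No measurement available here accounts for the drop.

This single step cannot separate the exchange of bromine for chlorine from the presence of a second halogen on the ring. The compounds shown also leave open how unsubstituted phenyl, 2-chlorophenyl or a pyridine ring would read at this position, and whether the hydroxy group on the same carbon matters to the result.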